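This account rests on a few compounds, and the source may have more. Where it says the series, first, only, none or still open, it means among the compounds named here.

Working notes on the series. Going by the values given here, in a physicochemical assay for acid dissociation, compound 1 `CC(C)N(C1=NCCN1)c1c(Br)cccc1Br` gives 11.2 and compound 2 `C=C(C)CN(C1=NCCN1)c1c(Br)cccc1Br` gives 10.7, which leaves compound 2 with the lower of the two numbers measured so far. The next structure is compound 3 `C=CCCN(C1=NCCN1)c1c(Br)cccc1Br`, still unmeasured. The change is allyl in place of 1-methylethenyl on a saturated chain carbon bound to a nitrogen on an aromatic ring. The two structures have the same atoms, joined differently, and cut one bond further out the change reads 2-methylprop-2-en-1-yl to but-3-en-1-yl.

Among the compounds with values here, only one measured step bears on this, and it is a modest one: a number 0.50 log units lower from compound 1 to compound 2 (beyond the scatter). That step exchanged isopropyl for 2-methylprop-2-en-1-yl on a nitrogen on an aromatic ring, so it replaced a different group from the one changed here and serves only as a rough guide to size. Within the data shown here, no measured pair isolates a rearrangement of this kind, so the direction rests on very little. No shift beyond the scatter is expected in this assay. The expected change is a number 0.10 log units higher from compound 2 to compound 3 (within the scatter). For compound 3 the estimated value is 10.8, with an expected range of 10.4 to 11.2.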

Compound 3, acid dissociation constant: 11.2
Beside the measured number, compound 3's estimate is 0.40 log units below it, and the stated range covers the measured number.
By their numbers in this assay, from the lowest: compound 2; then compounds 1 and 3 (each within the scatter of the next).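

In this assay, the rearrangement of the same atoms within the chain is not silent: a number 0.50 log units higher from compound 2 to compound 3 (beyond the scatter), a step as large as the only one measured before it, so this position responds to where the double bond and the branch sit and not only to which atoms are present. The second comparison gives no change at the digits printed from compound 1 to compound 3 (within the scatter), which leaves isopropyl and but-3-en-1-yl on a nitrogen on an aromatic ring inseparable here, and since compound 3 carries a double bond as compound 2 does, the presence of a double bond alone does not go with the lower number among these three compounds. Nothing on hand accounts for why 2-methylprop-2-en-1-yl stands apart from the other two groups.

Going by these compounds, whether the lower number of compound 2 follows the branch or the placing of the double bond stays open, and a saturated isobutyl or a cyclopropylmethyl group on a nitrogen on an aromatic ring would bear on that. Also open, on these data alone, is how a longer chain, or a chain ending in a hydroxyl or an amine, would read in this assay.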